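The compounds below may be only part of what the source reports. "The series", "measured", "known", "first", "only" and "open" are said of these compounds alone.

Compound 1 `Cc1ccc2ncc(S(=O)(=O)c3ccc(Cl)c(Cl)c3)c(N3CCC(C)CC3)c2c1` and compound 2 `CC1CCN(c2c(S(=O)(=O)c3ccc(Cl)c(Cl)c3)cnc3ccc(F)cc23)CC1` share a core in which a sulfonyl sulfur carries a 3,4-dichlorophenyl ring. For the measured compounds named here, in an assay on isolated protein for displacement of a labelled ligand from metabotropic glutamate receptor 5 (Homo sapiens), with a stated time of 60 min, tested at 1 uM (a lower number here means less inhibition, a higher number more inhibition at the concentration tested (going by the name of the read-out)), compound 1 gives 82% and compound 2 gives 91%; the only measured step, a number 9 percentage points higher from compound 1 to compound 2 (within the scatter), comes from a fluoro in place of a methyl on an aromatic carbon of the core, so the two numbers cannot be told apart. Compound 3 `Cc1ccc2ncc(S(=O)(=O)c3cccc(F)c3)c(N3CCC(C)CC3)c2c1` keeps the methyl-bearing core of compound 1 but changes the other side: 3-fluorophenyl in place of 3,4-dichlorophenyl on a sulfonyl sulfur. Going by the values given here, the one measured step does not touch this sulfonyl-bound ring and itself lies within the scatter, so nothing here tells how this assay responds to such a swap. Compound 1 gives 82% in this assay, and the estimate for compound 3 starts from that number with wide uncertainty in both directions. Compound 3 is expected to give 60%, within a range from 25% to 90%, meaning an expected step of a number 22 percentage points lower from compound 1 to compound 3 (beyond the scatter).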

Compound 3, a percentage reported as inhibition, at one concentration (the size of the read-out at that concentration, not a potency): 94%
Compound 3: the middle estimate sits 34 percentage points below what was measured; measured number outside the range, above it.
By their numbers in this assay, from the lowest: compounds 1, 2 and 3 (each within the scatter of the next, the first and the last beyond it).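

Until now the ring on the sulfonyl sulfur had not been varied. With the methyl-bearing core held fixed, putting 3-fluorophenyl in place of 3,4-dichlorophenyl at this position gives a number 12 percentage points higher from compound 1 to compound 3 (beyond the scatter) in this assay, so the two chlorines of compound 1 are not required for strong inhibition at the concentration tested, and the position accepts a ring with a single fluorine in their place. The compounds shown offer no information on why the number moves in this direction.

On these data alone, what stays open is how far this position can be pushed: a methoxy group or a nitrile in place of the fluorine on that ring might keep this level of inhibition or lose it, and the same holds for a ring with no substituent at all. It is also unknown whether the same swap on the fluoro-bearing core of compound 2 would give a similar step, and whether the step seen here would survive a full potency measurement, as a percentage at one concentration is not a potency.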